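The source may hold more compounds than are shown below. What is called first, only, known or untested is meant among the compounds shown, and "the series" means these compounds.

In a functional assay on BaF3 cells (Mus musculus) for inhibition, read by MTT assay, with a stated time of 3 days (a higher number here means a weaker inhibitor of growth, a lower number a stronger inhibitor of growth), compound 1 (`O=C(Nc1ccc(Nc2ncnc3c2OCCN3)cc1)Nc1cccc2ccccc12`) gives > 10000 nM as a limit of the assay and not a number. Compound 2 (`CC(C)(C)c1cc(NC(=O)Nc2ccc(Nc3ncnc4c3OCCN4)cc2)no1`) gives > 10000 nM as a limit too. Among the compounds with values here, compound 3 (`CC(C)(C)c1cc(NC(=O)Nc2ccc(Nc3ncnc4c3OCCN4)c(F)c2)no1`) gives 10000 nM as the only actual number in this set. The set so far is marked by the limit of > 10000 nM in this assay, at which 2 of the 3 values shown sit, in the record.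

Compound 4 (`Cc1cc(NC(=O)Nc2cc(C(C)(C)C)on2)ccc1Nc1ncnc2c1OCCN2`) differs from compound 3 by methyl in place of fluoro on an aromatic carbon with methyl in place of fluoro on an aromatic carbon, ortho to a large group and meta to a large group. The closer measured precedent is a number no higher from compound 2 to compound 3 (the limit leaves the size open) at that aromatic carbon. The other is a step that the two limits leave unreadable from compound 1 to compound 2 on an amide-type nitrogen. Neither has a readable size, and neither gives a direction.

With compound 3 at 10000 nM as the only anchor, the expectation is no change at the digits printed from compound 3 to compound 4 (within the scatter) as an estimated step, none beyond the scatter in this assay in either direction. For compound 4 the estimate is 10000 nM as the expected value, with 4000 nM to 20000 nM as the expected range. A report as a limit is also expected to be likely.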

Compound 4, concentration for 50% growth inhibition: > 10000 nM
Compound 4 was reported as a limit; the forecaster's own chance of this, stated with the estimate: 65%; the middle value sits exactly at the limit.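

At this aromatic carbon, methyl in place of fluoro gives a number no lower from compound 3 to compound 4 (the limit leaves the size open) in this assay. Hydrogen, fluoro and methyl have now all stood at this carbon, and methyl adds no second actual number to the set, while the steps between pairs bounded by two limits, including hydrogen to methyl, cannot be read. The set stays at the edge of the assay's range: the limit of > 10000 nM in this assay, at which 3 of the 4 values shown sit.

Open, as far as these compounds go, is whether a chloro or a methoxy group on this aromatic carbon would give a readable number in this assay. Also open, from the compounds shown here alone, is whether an amine or a carboxylic acid in place of the tert-butyl group would move the series off the limit, and so make the size of a change at this carbon readable.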